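This account rests on a few compounds, and the source may have more. Where it says the series, first, only, none or still open, it means among the compounds named here.

Compound 1 `Cc1c(OCCCCOc2ccc(C(=O)O)cc2F)ccc(C(=O)CC2CCCC2)c1O` gives 31.2% in an assay on HEK293 cells for positive allosteric modulation of metabotropic glutamate receptor 3 (Rattus norvegicus), read by thallium flux, with a stated time of 2.5 min (on this read-out lower numbers stand for smaller maximal responses and higher numbers for larger maximal responses), the lowest of the three measured numbers. Within the data shown here, compound 2 `CCCC(=O)c1ccc(OCCCCOc2ccc(F)c(C(=O)O)c2)c(C)c1O` gives 56.9% and compound 3 `Cc1c(OCCCCOc2ccc(C(=O)O)cc2F)ccc(C(=O)CC(C)C)c1O` gives 67.7%; the only single-place step on record, a number 36.5 percentage points higher from compound 1 to compound 3 (beyond the scatter), concerns the saturated chain carbon bound to a carbonyl carbon. Compound 4 `Cc1cc(OCCCCOc2ccc(C(=O)CC3CCCC3)c(O)c2C)ccc1C(=O)O` differs from compound 1 in another part of the molecule: 4-carboxy-3-methylphenyl in place of 4-carboxy-2-fluorophenyl on an oxygen on a saturated carbon. Among the measured compounds shown here, no measured step alters this group; compound 2 differs from compound 1 in more than one place, so its value shows only that a higher maximal response is reachable. The step from compound 1 to compound 4 is therefore expected to be a number 13.8 percentage points higher from compound 1 to compound 4 (beyond the scatter), with wide uncertainty. Compound 4 is estimated at 45%, within 25% to 70%.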

Compound 4, largest response reached (reported as percent of maximum), in percent of the reference or control that the assay uses: 23.7%
The estimate for compound 4 lay 21.3 percentage points above the measured number, and the stated range ends above it.
By their numbers in this assay, from the lowest: compounds 4 and 1 (each within the scatter of the next); then compound 2; then compound 3.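

In this assay, among these compounds, 4-carboxy-3-methylphenyl in place of 4-carboxy-2-fluorophenyl on an oxygen on a saturated carbon gives a number 7.5 percentage points lower from compound 1 to compound 4 (within the scatter), the first single-place reading at this group. This exchange therefore stays within the scatter, whereas the earlier step on the saturated chain carbon bound to a carbonyl carbon, a number 36.5 percentage points higher from compound 1 to compound 3 (beyond the scatter), does not. No supporting data bear on this result.

From the compounds shown here alone, whether the same exchange reads alike with the isopropyl group of compound 3 stays open. So does the outcome with a chlorine atom or a methoxy group on this ring, or with a tetrazole in place of the carboxylic acid.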